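Replacing 6-(thiophen-2-yl)pyridin-3-yl with 2-aminophenyl

This account rests on a few compounds, and the source may have more. Where it says the series, first, only, none or still open, it means among the compounds named here.

In a functional assay on HCT-116 cells (Homo sapiens) for inhibition, with a stated time of 72 h (on this read-out lower numbers stand for stronger inhibition and higher numbers for weaker inhibition), compound 1 `NC1CCC(Nc2nc(NCc3ccc(-c4ccco4)cc3)c3ncn(C4CCCC4)c3n2)CC1` gives 129 nM, compound 2 `NC1CCC(Nc2nc(NCc3ccc(-c4ccccc4)nc3)c3ncn(C4CCCC4)c3n2)CC1` gives 563 nM and compound 3 `NC1CCC(Nc2nc(NCc3ccc(-c4cccs4)nc3)c3ncn(C4CCCC4)c3n2)CC1` gives 97 nM. The numbers show a 1.3-fold lower number from compound 1 to compound 3 (0.12 log units; within the scatter), and a 5.8-fold lower number from compound 2 to compound 3 (0.76 log units; beyond the scatter), so compound 3 stands with compound 1 and clear of compound 2. Compound 4 `Nc1ccccc1CNc1nc(NC2CCC(N)CC2)nc2c1ncn2C1CCCC1` brings a larger change: 2-aminophenyl in place of 6-(thiophen-2-yl)pyridin-3-yl on a saturated chain carbon bound to a nitrogen on an aromatic ring. Going by the values given here, no measured step makes so large a change. The nearest guides are a 4.4-fold higher number from compound 1 to compound 2 (0.64 log units; beyond the scatter) and the step already given from compound 2, which show that smaller changes in this group can move the number beyond the scatter. A rise is therefore expected, with a 10-fold higher number from compound 3 to compound 4 (1.01 log units; beyond the scatter) as the estimated step. For compound 4 the estimate is 1000 nM, with an expected range of 200 nM to 5000 nM.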

Compound 4, half-maximal inhibitory concentration: 2300 nM
The estimate for compound 4 lay 2.3-fold (0.36 log units) below the measured number, within the range that was stated.
By their numbers in this assay, from the lowest: compounds 3 and 1 (each within the scatter of the next); then compound 2; then compound 4.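

In this assay, going by these compounds alone, the single-ring 2-aminophenyl group gives the highest number so far, with a 24-fold higher number from compound 3 to compound 4 (1.37 log units; beyond the scatter) and an 18-fold higher number from compound 1 to compound 4 (1.25 log units; beyond the scatter), both larger than any step among the two-ring groups. The rise from the weakest two-ring compound is smaller, with a 4.1-fold higher number from compound 2 to compound 4 (0.61 log units; beyond the scatter), so the size of the penalty depends on which two-ring group is replaced. No evidence here accounts for these rises.

The compounds shown leave open whether the amine or the absence of a second ring drives the change. A plain phenyl or a 2-hydroxyphenyl at this position would help separate the two.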